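Hydrazone aryl variation in a nicotinamide series: compound 4

This account rests on a few compounds, and the source may have more. Where it says the series, first, only, none or still open, it means among the compounds named here.

Measured compounds:
compound 1 `O=C(N/N=C/c1cccc(F)c1)c1cccnc1Nc1cccc(C(F)(F)F)c1`: 29.8%
compound 2 `O=C(N/N=C/c1ccc(Cl)cc1)c1cccnc1Nc1cccc(C(F)(F)F)c1`: 43.7%
compound 3 `O=C(N/N=C/c1ccc(O)cc1)c1cccnc1Nc1cccc(C(F)(F)F)c1`: 61.6%

All three were run in a functional assay on the whole organism (strain Wistar) for inhibition, with Rattus norvegicus as the target, read by paw edema, with a stated time of 4 h, at a dose of 10 mg/kg by the intraperitoneal route; on this read-out higher numbers stand for more inhibition at the one dose given (going by the name of the read-out) and lower numbers for less inhibition. Compound 3 stands highest of the three, with compound 2 nearest and compound 1 furthest; its steps to both lie beyond the scatter. Compound 4 `COc1cccc(/C=N/NC(=O)c2cccnc2Nc2cccc(C(F)(F)F)c2)c1` is not yet measured. It differs from compound 3 as follows: 3-methoxyphenyl in place of 4-hydroxyphenyl on a carbon with a double bond to nitrogen.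

Among the measured compounds shown here, no measured step swaps a hydroxy for a methoxy, so the bearing of the earlier steps is indirect. For the measured compounds named here, two steps concern the aryl on the carbon with a double bond to nitrogen: a number 31.8 percentage points higher from compound 1 to compound 3 (beyond the scatter) and a number 17.9 percentage points higher from compound 2 to compound 3 (beyond the scatter), both rising towards the 4-hydroxyphenyl of compound 3. Compound 4 gives up that group, and the two compounds without it, compound 1 and compound 2, both sit well below compound 3. A downward step in this assay is therefore expected, though how far a 3-methoxyphenyl would fall is uncertain.

For compound 4 the expected step is a number 23.6 percentage points lower from compound 3 to compound 4 (beyond the scatter). Compound 4 is estimated at 38%, with a range from 22% to 55%.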

Compound 4, a percentage reported as inhibition, in the whole organism at one dose (the size of the read-out at that dose, not a potency): 14.9%
Compound 4: middle estimate off by 23.1 percentage points, on the high side, outside the stated range (below it).
By their numbers in this assay, from the lowest: compound 4; then compound 1; then compound 2; then compound 3.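

In this assay, the 3-methoxyphenyl on the carbon with a double bond to nitrogen gives a large fall, a number 46.7 percentage points lower from compound 3 to compound 4 (beyond the scatter), the widest gap seen so far at this position. The fall continues past the two halogen-bearing aryls, with a number 28.8 percentage points lower from compound 2 to compound 4 (beyond the scatter) and, for methoxy in place of fluoro, a number 14.9 percentage points lower from compound 1 to compound 4 (beyond the scatter), so removing the 4-hydroxyphenyl does not by itself set the level: the aryl that replaces it still matters, and compound 4 stands lowest of the four. No measurement shown here accounts for this order.

The change from 4-hydroxyphenyl to 3-methoxyphenyl alters both the group on the aryl and its place, and these two changes cannot be separated here. Going by these compounds, whether an amine or a carboxylic acid on the aryl would track the hydroxy of compound 3 also remains open.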